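Urea in place of amide on the shared core

A few compounds are considered here, and "the series" means these few. Any claim that something is new, unique, unknown or untested is made for them only; others in the source may bear on it.

Measured so far in a functional assay on T47D cells (Homo sapiens) for inhibition, read by sulforhodamine B assay, with a stated time of 48 h; on this read-out higher numbers stand for lower toxicity in this test and lower numbers for higher toxicity in this test:
- compound 1 `O=C(Nc1cccc(-n2cc(-c3ccncc3)c(-c3ccc(Cl)c(O)c3)n2)c1)Nc1ccc(Cl)c(Cl)c1` gives > 32500 nM, a limit of the assay and not a number.
- compound 2 `COc1cc(-c2nn(-c3cccc(NC(=O)c4cccc(C(F)(F)F)c4)c3)cc2-c2ccncc2)ccc1Cl` gives > 50000 nM, a limit of the assay and not a number.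
- compound 3 `O=C(Nc1cccc(-n2cc(-c3ccncc3)c(-c3ccc(Cl)c(O)c3)n2)c1)Nc1cc(C(F)(F)F)cc(C(F)(F)F)c1` gives > 50000 nM, a limit of the assay and not a number.

Compound 2 therefore stands at a limit only, and the two further values shown are limits as well, so no real number is known for any compound in this assay. The limits are the limit of > 32500 nM in this assay, at which 1 of the 3 values shown sits, and (the limit of > 50000 nM in this assay, at which 2 of the 3 values shown sit). Going by the values given here, no two measured compounds differ in a single place, so no measured step is available.

Compound 4 `COc1cc(-c2nn(-c3cccc(NC(=O)Nc4ccc(Cl)c(C(F)(F)F)c4)c3)cc2-c2ccncc2)ccc1Cl` is not yet measured. It differs from compound 2 in one place: (4-chloro-3-(trifluoromethyl)phenyl)amino in place of 3-(trifluoromethyl)phenyl on a carbonyl carbon. Compound 1 and compound 3 carry a urea of a related kind on a different core, and both sit at limits. For compound 4 no change beyond the scatter is expected in either direction. The expected step is a number no higher from compound 2 to compound 4 (the limit leaves the size open). Compound 4 is estimated at 50000 nM, in the range 15000 nM to 150000 nM, and most probably reported again only as a limit.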

Compound 4, concentration lethal to 50% of the cells: > 32500 nM
Compound 4: no number, only a limit; the forecaster's own chance of this, stated with the estimate: 85%; the middle value does not contradict the limit.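

Going by these compounds alone, compound 2 and compound 4 are both reported only as limits of the assay, so no step between them can be read in this assay. With no real number for any compound shown, it stays open how toxic any of them is in this assay, and whether the urea of compound 4 changes that at all.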